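The compounds below may be only part of what the source reports. "The series", "measured", "known", "first", "only" and "open" are said of these compounds alone.

Measured compounds in a functional assay for antagonist activity at 5-hydroxytryptamine receptor 4 (Rattus norvegicus); on this read-out higher numbers stand for higher potency (the scale is a negative logarithm) and lower numbers for lower potency:
compound 1 `COc1cc(COc2cc(N)c(Cl)cc2C(=O)CCCCN2CCC(C)CC2)cc(OC)c1` gives 8.3
compound 2 `CCCCN1CCC(CCC(=O)c2cc(Cl)c(N)cc2OCc2cc(OC)cc(OC)c2)CC1` gives 8.9
compound 3 `CCCCCN1CCC(CCC(=O)c2cc(Cl)c(N)cc2OCc2cc(OC)cc(OC)c2)CC1` gives 9.1

Compound 3 stands highest of the three numbers, though its gap to compound 2 is within the scatter; only the gap to compound 1 is beyond it. The unmeasured compound 4 `COc1cc(COc2cc(N)c(Cl)cc2C(=O)CCC2CCN(CCN(C)S(C)(=O)=O)CC2)cc(OC)c1` differs from compound 3 by methyl(methylsulfonyl)amino in place of propyl on a saturated chain carbon, two bonds along the chain from an amine nitrogen in a ring. The one measured step that bears on a change at this part of the chain, a number 0.20 log units higher from compound 2 to compound 3 (within the scatter), was small, and no measured step introduces a group of this kind, so the direction of the effect is not shown. Compound 4 is therefore expected near compound 3, with the step of a number 0.40 log units lower from compound 3 to compound 4 (beyond the scatter) estimated as small, and an estimated value of 8.7 within 8 to 9.4.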

Compound 4, negative logarithm of the antagonist equilibrium constant: 9.1
Compound 4: middle estimate off by 0.40 log units, on the low side; the measured number falls inside the stated range.
By their numbers in this assay, from the lowest: compound 1; then compounds 2, 3 and 4 (each within the scatter of the next).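

In this assay, among these compounds, methyl(methylsulfonyl)amino in place of propyl, on a saturated chain carbon two bonds along the chain from an amine nitrogen in a ring, gave no change at the digits printed from compound 3 to compound 4 (within the scatter), so this position accepted a group containing nitrogen, sulfur and oxygen, where the earlier compounds carried only carbon chains. The change in place of ethyl gave a number 0.20 log units higher from compound 2 to compound 4 (within the scatter), which agrees with that reading. Nothing shown gives a reason for this result.

From the compounds shown here alone, it remains open whether a carboxylic acid or a primary amine at this position would leave the number similarly unchanged. A longer chain ending in the same methyl(methylsulfonyl)amino group is also untested among these compounds.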